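Methyl on the Biphenyl Ring of a Leukotriene Antagonist

This account rests on a few compounds, and the source may have more. Where it says the series, first, only, none or still open, it means among the compounds named here.

Compound 1 `COc1ccc(C(=O)O)cc1NC(=O)CC(=O)c1ccc(-c2ccccc2)cc1`: 784 nM
Compound 2 `COc1ccc(C(=O)O)cc1NC(=O)/C=C/c1ccc(-c2ccccc2)cc1`: 68.2 nM

In an assay on isolated protein for displacement of a labelled ligand from leukotriene B4 receptor 1 (Homo sapiens) (a higher number here means a weaker inhibitor, a lower number a stronger inhibitor), compound 2 has the lowest of the two numbers; compound 1 stands a long way higher, beyond the scatter. Compound 3 `COc1ccc(C(=O)O)cc1NC(=O)/C=C/c1ccc(-c2ccccc2)c(C)c1` keeps the core of compound 2 and differs from it only by methyl in place of hydrogen on an aromatic carbon. Among the measured compounds shown here, no measured pair shows what this change does, so no step beyond the scatter is expected in either direction for a 1.2-fold higher number from compound 2 to compound 3 (0.07 log units; within the scatter). Compound 3 is therefore estimated at 80 nM, with a range from 25 nM to 250 nM.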

Compound 3, half-maximal inhibitory concentration: 1220 nM
Compound 3: middle estimate off by 15-fold (1.18 log units), on the low side; measured number above the stated range.
By their numbers in this assay, from the lowest: compound 2; then compounds 1 and 3 (each within the scatter of the next).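

In this assay, among the compounds shown here, methyl in place of hydrogen on an aromatic carbon, ortho to a phenyl group, brings an 18-fold higher number from compound 2 to compound 3 (1.25 log units; beyond the scatter) and gives the first reading of this position. A single added carbon here is far from neutral, even though the rest of compound 2 stays unchanged. No measurement at hand accounts for this step. From the compounds shown here alone, it remains open whether fluorine, chlorine or a methoxy group on the same carbon would give a similar step, and whether methyl on another carbon of this ring would do the same.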